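Where the iodo group sits: compound 1 to compound 3

The source may report more compounds than this note shows. Statements on the series, on what has been measured and on what is new or still open speak of the compounds shown alone.

Compound 1 `C/C(=N/NC(=S)Nc1ccccc1)c1ccccn1` is the parent of this small set. In a functional assay on U-87MG ATCC cells (Homo sapiens) for cytotoxicity, read by MTT assay, with a stated time of 48 h (a higher number here means a weaker inhibitor, a lower number a stronger inhibitor), compound 1 gives 1.4 nM, the lowest of the two numbers recorded so far, so it is the stronger of the two measured compounds. Compound 2 `C/C(=N/NC(=S)Nc1ccccc1I)c1ccccn1` carries an iodo group; in this assay compound 2 gives 6.1 nM. Among the compounds with values here, the step of a 4.4-fold higher number from compound 1 to compound 2 (0.64 log units; beyond the scatter) is the only measured comparison and bears directly on the new case. Compound 3 `C/C(=N/NC(=S)Nc1cccc(I)c1)c1ccccn1` differs from compound 1 by iodo in place of hydrogen on an aromatic carbon. With one iodo substitution already seen to give a higher number, an upward step beyond the scatter is expected here too, though its size in this assay is uncertain, and the estimated step is a 2.9-fold higher number from compound 1 to compound 3 (0.46 log units; beyond the scatter). Compound 3 is therefore expected to give about 4 nM, with a range from 1.5 nM to 12 nM.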

Compound 3, half-maximal inhibitory concentration: 84 nM
Estimate against measurement, compound 3: 21-fold (1.32 log units) below; measured number above the stated range.
By their numbers in this assay, from the lowest: compound 1; then compound 2; then compound 3.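

In this assay, putting iodo in place of hydrogen on this aromatic carbon, meta to a large group, gives a 60-fold higher number from compound 1 to compound 3 (1.78 log units; beyond the scatter), a large step. The same exchange on a different carbon of the same ring, in compound 2, gives only a 4.4-fold higher number from compound 1 to compound 2 (0.64 log units; beyond the scatter), so in these compounds the size of the step depends on where the iodo group sits and not merely on its presence. Nothing measured here gives a reason for this dependence on position.

Going by these compounds, it remains open whether the large step belongs to iodo itself or would appear with any group on this carbon. A fluoro, methoxy or amine group in the same place would show whether other substituents follow compound 3 or stay closer to compound 1.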